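Little Left to Lose in Mouse Microsomes

This account rests on a few compounds, and the source may have more. Where it says the series, first, only, none or still open, it means among the compounds named here.

Measured in an ADME assay on microsomes from liver (Mus musculus) for metabolic stability, with a stated time of 10 min; a higher number here means that more of the compound is left, a lower number that less of the compound is left:
Compound 1 `O=C(O)C1CCC(O)(C(=O)N2CC[C@](c3ccc(C(F)(C(F)(F)F)C(F)(F)F)cc3)(S(=O)(=O)c3ccc(F)cc3)C2)CC1`: 99%; 98% (2 entries)
Compound 2 `O=C(O)C12CCC(C(=O)N3CC[C@](c4ccc(C(F)(C(F)(F)F)C(F)(F)F)cc4)(S(=O)(=O)c4ccc(F)cc4)C3)(CC1)OC2`: 94%
Compound 3 `O=C(C1CCS(=O)(=O)CC1)N1CC[C@](c2ccc(C(F)(C(F)(F)F)C(F)(F)F)cc2)(S(=O)(=O)c2ccc(F)cc2)C1`: 96%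

Compound 3 stands level with compound 2 within the scatter, as the step of a number 2 percentage points higher from compound 2 to compound 3 (within the scatter) shows, and the repeat entries, (the several entries of compound 1 in this assay, 99%; 98% (2 entries)), agree closely. Compound 4 `O=C(N1CC[C@](c2ccc(C(F)(C(F)(F)F)C(F)(F)F)cc2)(S(=O)(=O)c2ccc(F)cc2)C1)C1(CO)CCS(=O)(=O)CC1` carries one change, hydroxymethyl in place of hydrogen on a saturated ring carbon. Among the compounds with values here, no measured step covers this exact change. The nearest, a number 2 percentage points higher from compound 2 to compound 3 (within the scatter), replaced a whole group on a carbonyl carbon and stayed small, so no shift beyond the scatter is expected in this assay. The expected step is a number 2 percentage points lower from compound 3 to compound 4 (within the scatter). For compound 4 the estimated value is 94%, with an expected range from 85% to 100%.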

Compound 4, percent of the compound remaining: 31%
Estimate against measurement, compound 4: 63 percentage points above; the measured number lies below the stated range.
By their numbers in this assay, from the lowest: compound 4; then compounds 2 and 3 (each within the scatter of the next).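

In this assay, hydroxymethyl on this saturated ring carbon, three ring bonds from the ring sulfur, gave a number 65 percentage points lower from compound 3 to compound 4 (beyond the scatter), so this small addition mattered far more than the earlier exchange of a whole group on the carbonyl carbon. The same gap appears in a number 63 percentage points lower from compound 2 to compound 4 (beyond the scatter). Nothing given here accounts for the loss. The compounds shown leave open whether the hydroxyl or the added carbon carries the effect. A methyl or an aminomethyl group on this same carbon would help separate the two.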